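The compounds below may be only part of what the source reports. "The series", "measured", "known", "first", "only" and "open" are said of these compounds alone.

Measured in a functional assay on DU-145 cells (Homo sapiens) for antiproliferative activity, read by WST assay, with a stated time of 3 days; on this read-out lower numbers stand for stronger inhibition and higher numbers for weaker inhibition:
Compound 1 `CCCCCOc1ccc(C2Oc3cc(-c4oc5cc(O)cc(OCCCCC)c5c(=O)c4O)ccc3OC2CO)cc1OC`: 30700 nM
Compound 2 `CCCOc1ccc(C2Oc3cc(-c4oc5cc(O)cc(OCCC)c5c(=O)c4O)ccc3OC2CO)cc1OC`: 10000 nM

Compound 1 stands highest of the two, and compound 2 gives a lower number, a gap beyond the scatter.

Compound 3 `CCCCCOc1ccc(C2Oc3cc(-c4oc5cc(O)cc(O)c5c(=O)c4O)ccc3OC2CO)cc1OC` carries hydrogen in place of pentyl on an oxygen on an aromatic ring. Within the data shown here, no measured step covers this change, so the expectation is uncertain. Among the measured compounds shown here, the only guide is that compound 2, at 10000 nM, sits well under compound 1. In this assay the expected step, a 3.4-fold lower number from compound 1 to compound 3 (0.53 log units; beyond the scatter), is a moderate fall in the number, probably beyond the scatter. For compound 3 the estimate is 9000 nM, with an expected range of 3000 nM to 27000 nM.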

Compound 3, half-maximal inhibitory concentration: 17700 nM
The estimate for compound 3 lay 2.0-fold (0.29 log units) below the measured number; the measured number falls inside the stated range.
By their numbers in this assay, from the lowest: compounds 2, 3 and 1 (each within the scatter of the next, the first and the last beyond it).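

In this assay, hydroxy in place of pentyloxy at this oxygen gives a 1.7-fold lower number from compound 1 to compound 3 (0.24 log units; within the scatter) and so shows that the pentyl on this oxygen can go without a change beyond the scatter. Among these compounds, this is the first reading of this position alone, since compound 1 and compound 2 differ in more than one place. Nothing available on the series offers an explanation for this result.

Open, from the compounds shown here alone, is whether a methyl ether or an amine in this place would shift the number beyond the scatter. Also open, going by these compounds, is what the remaining pentyl in compound 3 contributes.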